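The compounds below may be only part of what the source reports. "The series", "measured", "known", "first", "only" and "open" are said of these compounds alone.

Compound 1 `CN(C)C1CCN(C(=O)CCCOc2cc(C(=O)N3CCCCc4sccc43)ccc2NC(=O)c2ccccc2-c2ccccc2)CC1`: 20 nM. Compound 2 `CN1CCCN(CCCOc2cc(C(=O)N3CCCCc4sccc43)ccc2NC(=O)c2ccccc2-c2ccccc2)CC1`: 2 nM.

Among the measured compounds shown here, in an assay on CHO cells for inhibition of Vasopressin V2 receptor (Homo sapiens), read by radioligand binding (on this read-out higher numbers stand for weaker inhibition and lower numbers for stronger inhibition), compound 1 gives 20 nM, the higher of the two numbers; compound 2 gives 2 nM, and the single measured step is a 10-fold lower number from compound 1 to compound 2 (1.00 log units; beyond the scatter). Compound 3 `CCN(CC)C1CCN(C(=O)CCCOc2cc(C(=O)N3CCCCc4sccc43)ccc2NC(=O)c2ccccc2-c2ccccc2)CC1` differs from compound 1 by diethylamino in place of dimethylamino on a saturated ring carbon. For the measured compounds named here, that measured step exchanges the whole (4-(dimethylamino)piperidin-1-yl)carbonyl for 4-methyl-1,4-diazepan-1-yl, not the amine on the piperidine ring, so it bears only loosely on this change; no step touches the dimethylamino itself. Compound 3 is therefore expected to stay close to compound 1, with no change at the digits printed from compound 1 to compound 3 (within the scatter) within the scatter. Estimate for compound 3: 20 nM, range 7 nM to 55 nM.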

Compound 3, half-maximal inhibitory concentration: 9 nM
Compound 3: the middle estimate sits 2.2-fold (0.35 log units) above what was measured, and the stated range covers the measured number.
By their numbers in this assay, from the lowest: compound 2; then compound 3; then compound 1.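

In this assay the amine on the saturated ring carbon, three ring bonds from the ring nitrogen, affects the read-out by itself: diethylamino in place of dimethylamino gives a 2.2-fold lower number from compound 1 to compound 3 (0.35 log units; beyond the scatter) and lies beyond the scatter, though the step is modest. Among the compounds shown here, the earlier step exchanged the whole (4-(dimethylamino)piperidin-1-yl)carbonyl, so this is the first read on the amine alone. Nothing available explains the step.

Open, on these data alone, is how a pyrrolidine or morpholine on that carbon would read. Also open, as far as these compounds go, is whether dipropylamino would move the number further.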